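Swapping a methoxy for fluorine on a thiazolidinone scaffold

The compounds below may be only part of what the source reports. "The series", "measured", "known", "first", "only" and "open" are said of these compounds alone.

Two close relatives share one core. Compound 2 `COc1ccc(/C=C2\S/C(=N\c3nc(-c4ccc(Cl)cc4)cs3)NC2=O)cc1` carries a methoxy group on its outer benzene ring, while compound 1 `Cc1ccc(/C=C2\S/C(=N\c3nc(-c4ccc(Cl)cc4)cs3)NC2=O)cc1` carries a methyl group at the same spot. In a functional assay on HCT-116 cells (Homo sapiens) for cytotoxicity, read by MTT assay, with a stated time of 72 h (on this read-out higher numbers stand for weaker inhibition and lower numbers for stronger inhibition), compound 1 gives 500 nM, and compound 2 gives 400 nM. Among the compounds with values here, the only measured step, a 1.3-fold lower number from compound 1 to compound 2 (0.10 log units; within the scatter), lies within the scatter, so the two numbers count as the same, and compound 2 stands alongside compound 1 rather than apart from it.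

Compound 3 `O=C1N/C(=N/c2nc(-c3ccc(Cl)cc3)cs2)S/C1=C\c1ccc(F)cc1` is the next variation: fluoro in place of methoxy on an aromatic carbon. Within the data shown here, the one step seen so far, from methyl to methoxy, bears on this change in that it also swapped a small group at that position and moved nothing beyond the scatter. From that, no step beyond the scatter is expected, and the estimate for compound 3 is 500 nM, with a range of 200 nM to 1300 nM, meaning an expected step of a 1.3-fold higher number from compound 2 to compound 3 (0.10 log units; within the scatter).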

Compound 3, half-maximal inhibitory concentration: 7500 nM
Estimate against measurement, compound 3: 15-fold (1.18 log units) below; the measured number lies above the stated range.
By their numbers in this assay, from the lowest: compounds 2 and 1 (each within the scatter of the next); then compound 3.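

This position is not indifferent to the group it carries. In this assay, methyl and methoxy could not be told apart, yet the change to fluoro brings a 19-fold higher number from compound 2 to compound 3 (1.27 log units; beyond the scatter) and a 15-fold higher number from compound 1 to compound 3 (1.18 log units; beyond the scatter) on the same read-out, so inhibition is clearly weaker with the 4-fluorophenyl group. A swap of one small group for another can therefore matter greatly here, although the first step gave no sign of it, and nothing available explains why this change has so large an effect.

Still open, going by these compounds, is whether bromo, hydroxyl or an amine at this place would sit with compound 1 and compound 2 or with compound 3. Three compounds also cannot show whether the gap is specific to fluoro or would recur on a different cell line.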